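Propoxy to Ethoxy: An Expected Step

The source may report more compounds than this note shows. Statements on the series, on what has been measured and on what is new or still open speak of the compounds shown alone.

Measured so far in a physicochemical assay for lipophilicity, at pH 7.4; a higher number here means a more lipophilic compound, a lower number a more polar compound:
- compound 1 `CCOC(=O)[C@@H](N)CCC(=O)NCCSC(=O)C(C)(C)C`: -0.29
- compound 2 `CCCOC(=O)[C@@H](N)CCC(=O)NCCSC(C)=O`: -1.21

Compound 2, at -1.21, is the lower of the two, and the gap up to compound 1 lies beyond the usual scatter. Compound 3 `CCOC(=O)[C@@H](N)CCC(=O)NCCSC(C)=O` is still unmeasured. It differs from compound 2 by one change hydrogen in place of methyl on a saturated chain carbon, two bonds along the chain from an oxygen next to a carbonyl group, which reads as propoxy to ethoxy. Going by the values given here, no measured pair shows this change. A modest fall in this assay, just beyond the scatter, is expected, a number 0.44 log units lower from compound 2 to compound 3 (beyond the scatter). The estimate for compound 3 is -1.65, with an expected range from -2.05 to -1.3.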

Compound 3, distribution coefficient: -1.44
Compound 3: middle estimate off by 0.21 log units, on the low side; low and high end bracket the measured number.
By their numbers in this assay, from the lowest: compounds 3 and 2 (each within the scatter of the next); then compound 1.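

Going from propoxy to ethoxy gives a number 0.23 log units lower from compound 2 to compound 3 (within the scatter), so in this assay this change does not separate the two compounds at this position. Methyl in place of tert-butyl on a carbonyl carbon gives a number 1.15 log units lower from compound 1 to compound 3 (beyond the scatter), which makes the thioester end, not the ester chain, the place where a one-place change has shown a clear step so far. Nothing available explains either step. Going by these compounds, a longer chain such as butoxy, or a carboxylic acid in place of the ester, remains open. So does an intermediate isopropyl group on that carbonyl carbon.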